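A few compounds are considered here, and "the series" means these few. Any claim that something is new, unique, unknown or untested is made for them only; others in the source may bear on it.

Measured compounds: compound 1 `CCCCNc1nc(-c2ccccc2)nc2c1nnn2Cc1ccccc1C(F)(F)F` gives 6500000 nM; compound 2 `c1ccc(Cn2nnc3c(NC4CCCC4)nc(-c4ccccc4)nc32)cc1` gives 11000000 nM; compound 3 `CCCCNc1nc(-c2ccccc2)nc2c1nnn2Cc1ccccc1` gives 11000000 nM, all in an assay on isolated protein for binding affinity to adenosine receptor A1 (Bos taurus); a higher number here means a weaker inhibitor, a lower number a stronger inhibitor.

Compound 2 and compound 3 share a core and differ only in that (cyclopentyl in place of butyl on a nitrogen on an aromatic ring); in this assay the two sit level, with no change at the digits printed from compound 2 to compound 3 (within the scatter). The step from compound 3 to compound 1 is trifluoromethyl in place of hydrogen on an aromatic carbon, and it gave a 1.7-fold lower number from compound 3 to compound 1 (0.23 log units; within the scatter). Compound 4 `FC(F)(F)c1ccccc1Cn1nnc2c(NC3CCCC3)nc(-c3ccccc3)nc21` arises from compound 2 by the same change, (trifluoromethyl in place of hydrogen on an aromatic carbon). Going by the values given here, since the one measured instance of this change stayed within the scatter, compound 4 is expected to behave much as compound 2 does, with an expected step of a 1.6-fold lower number from compound 2 to compound 4 (0.20 log units; within the scatter). The estimate for compound 4 in this assay is 7000000 nM, with a range from 3000000 nM to 16000000 nM.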

Compound 4, inhibition constant: 600000 nM
Compound 4: the middle estimate sits 12-fold (1.07 log units) above what was measured, outside the stated range (below it).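

In this assay, trifluoromethyl in place of hydrogen gave an 18-fold lower number from compound 2 to compound 4 (1.26 log units; beyond the scatter), so the size of this step did not carry over from the butyl series to the cyclopentyl series: the same change on two cores in this assay, a 1.7-fold lower number (0.23 log units; within the scatter) from compound 3 to compound 1 and an 18-fold lower number (1.26 log units; beyond the scatter) from compound 2 to compound 4, 11-fold (1.03 log units) apart, beyond the scatter of two such steps. Cyclopentyl in place of butyl likewise depended on its setting, giving an 11-fold lower number from compound 1 to compound 4 (1.03 log units; beyond the scatter) with trifluoromethyl present: the same change on two cores in this assay, no change at the digits printed (within the scatter) from compound 2 to compound 3 and an 11-fold higher number (1.03 log units; beyond the scatter) from compound 4 to compound 1, 11-fold (1.03 log units) apart, beyond the scatter of two such steps. Across these four compounds, the two changes therefore do not act independently, but this rests on a single set of pairs and does not show why they combine this way or whether the pattern extends to other compounds.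

Going by these compounds, it remains open whether a chlorine or a methyl in place of trifluoromethyl would give a similar step alongside cyclopentyl. The same question stands for a cyclohexyl or a longer chain in place of cyclopentyl alongside trifluoromethyl.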